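Series notes: the phenoxy analogue, compound 4

The source may report more compounds than this note shows. Statements on the series, on what has been measured and on what is new or still open speak of the compounds shown alone.

Measured so far in a functional assay for inhibition of sodium/hydrogen exchanger (Oryctolagus cuniculus); a lower number here means a stronger inhibitor, a higher number a weaker inhibitor:
compound 1 `Cc1cc(-c2ccc(Cl)cc2)c(S(C)(=O)=O)cc1C(=O)N=C(N)N`, 45 nM
compound 2 `Cc1cc(-c2ccco2)c(S(C)(=O)=O)cc1C(=O)N=C(N)N`, 16 nM
compound 3 `Cc1cc(Sc2ccncc2)c(S(C)(=O)=O)cc1C(=O)N=C(N)N`, 13 nM

Compound 3 gives the lowest number of the three; compound 2 sits within the scatter of it, while compound 1 is the furthest away, as the step of a 3.5-fold lower number from compound 1 to compound 3 (0.54 log units; beyond the scatter) shows. The step of a 2.8-fold lower number from compound 1 to compound 2 (0.45 log units; beyond the scatter) is of the same size, and the step of a 1.2-fold lower number from compound 2 to compound 3 (0.09 log units; within the scatter) is within the scatter.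

Compound 4 `Cc1cc(Oc2ccccc2)c(S(C)(=O)=O)cc1C(=O)N=C(N)N` differs from compound 3 in one place: phenoxy in place of (pyridin-4-yl)sulfanyl on an aromatic carbon. Among the measured compounds shown here, the step from compound 1 to compound 3, which also exchanged a carbon-only six-membered ring for the (pyridin-4-yl)sulfanyl group, is the one that bears on this change; no measured step covers a phenoxy group. Returning to a carbon-only ring is therefore expected to move the number back towards that of compound 1, by a modest step of a 1.9-fold higher number from compound 3 to compound 4 (0.28 log units; within the scatter).

Compound 4 is estimated at 25 nM, with a range of 10 nM to 70 nM.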

Compound 4, half-maximal inhibitory concentration: 10 nM
Compound 4: the middle estimate sits 2.5-fold (0.40 log units) above what was measured; measured number inside the range.
By their numbers in this assay, from the lowest: compounds 4, 3 and 2 (each within the scatter of the next); then compound 1.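

In this assay, a 1.3-fold lower number from compound 3 to compound 4 (0.11 log units; within the scatter) and a 1.6-fold lower number from compound 2 to compound 4 (0.20 log units; within the scatter) both stay within the scatter, so at this place, ortho to the methylsulfonyl group, a carbon-only ring carried through oxygen matches the pyridine ring carried through sulfur. Against the directly attached 4-chlorophenyl, a 4.5-fold lower number from compound 1 to compound 4 (0.65 log units; beyond the scatter) lies beyond the scatter. No measurement on hand explains these steps. The compounds shown do not separate the oxygen link from the loss of chlorine in that last step. As far as these compounds go, how an amine or a carboxylic acid would fare at this place remains open.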